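A few compounds are considered here, and "the series" means these few. Any claim that something is new, unique, unknown or untested is made for them only; others in the source may bear on it.

Of the compounds shown here, three on the shared core have been read in an ADME assay on HEK293 cells (Homo sapiens) for cytotoxicity, with a stated time of 72 h; on this read-out lower numbers stand for an effect already at smaller amounts and higher numbers for an effect only at larger amounts of compound. Compound 1 (`Cc1cc(NC(=O)Nc2ccc(C(C)(C)C)cc2)c2ccccc2n1`) gives > 25000 nM, a limit of the assay. Compound 3 (`COc1ccc(NC(=O)Nc2cc(C)nc3ccccc23)cc1OC`) gives > 25000 nM, also a limit. Compound 2 (`Cc1cc(NC(=O)Nc2ccccc2OC(F)(F)F)c2ccccc2n1`) gives > 25000 nM, again a limit and not a number, so it stands with the other two: the limit of > 25000 nM in this assay, at which 3 of the 3 values shown sit. Compound 4 (`Cc1cc(NC(=O)Nc2ccccc2C(C)(C)C)c2ccccc2n1`) differs from compound 2 in one place: tert-butyl in place of trifluoromethoxy on an aromatic carbon. Among the compounds with values here, no measured step gives the size of such a change. With compound 2 at the limit > 25000 nM, no step beyond the scatter is expected in this assay. The expected step that the limit leaves unreadable from compound 2 to compound 4 stays within the scatter. For compound 4 the estimate is 30000 nM, with an expected range of 15000 nM to 60000 nM.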

Compound 4, half-maximal effective concentration: > 25000 nM
Compound 4 gave a limit, no number; the forecaster's own chance of this, stated with the estimate: 85%; the middle value is on the limit's open side.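

Compound 2 and compound 4 both stand as limits and not as numbers, so no step between them can be read: the limit of > 25000 nM in this assay, at which 4 of the 4 values shown sit.

The compounds shown leave open which change on the shared core, if any, would give a readable number in this assay.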